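Benzyl Ester to Free Acid: A Repeated Change

The source may hold more compounds than are shown below. What is called first, only, known or untested is meant among the compounds shown, and "the series" means these compounds.

Of the compounds shown here, three have been tested in a functional assay on the whole organism (Tail, strain ICR) with Mus musculus as the target, in the tail flick test, with a stated time of 60 min, at a dose of 25 umol/kg by the oral route; a lower number here means a weaker effect, a higher number a stronger effect of the compound at the dose given. Compound 1 `O=C(CN(c1nc(Cl)nc2[nH]cnc12)C1CC1)N[C@@H](CO)C(=O)OCc1ccccc1` gives 34.2%. Compound 2 `O=C(CN(c1nc(Cl)nc2[nH]cnc12)C1CC1)N[C@@H](CO)C(=O)O` gives 39.8%. Compound 3 `CC(C)C[C@H](NC(=O)CN(c1nc(Cl)nc2[nH]cnc12)C1CC1)C(=O)OCc1ccccc1` gives 27.3%. Compound 2 arises from compound 1 by hydrogen in place of benzyl on an oxygen next to a carbonyl group, a change that made a number 5.6 percentage points higher from compound 1 to compound 2 (within the scatter). The core of compound 3 differs from the core of compound 1 by isopropyl in place of hydroxy on a saturated chain carbon, two bonds along the chain from an amide-type nitrogen and a carbonyl carbon. Compound 4 `CC(C)C[C@H](NC(=O)CN(c1nc(Cl)nc2[nH]cnc12)C1CC1)C(=O)O` has not yet been measured. It arises from compound 3 by hydrogen in place of benzyl on an oxygen next to a carbonyl group, which is the same change as from compound 1 to compound 2, at the same place. Because the earlier example moved only a number 5.6 percentage points higher from compound 1 to compound 2 (within the scatter), a similarly small step is expected here. Compound 4 is estimated to reach 33% in this assay, most likely between 22% and 44%. This expectation corresponds to a step of a number 5.7 percentage points higher from compound 3 to compound 4 (within the scatter).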

Compound 4, a percentage reported as activity, at one dose (the size of the read-out at that dose, not a potency): 36.4%
For compound 4 the middle estimate is 3.4 percentage points below the measured one; the range from low to high includes it.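

In this assay, hydrogen in place of benzyl gives a number 9.1 percentage points higher from compound 3 to compound 4 (within the scatter), and the two cores agree on this change: the same change on two cores in this assay, a number 5.6 percentage points higher (within the scatter) from compound 1 to compound 2 and a number 9.1 percentage points higher (within the scatter) from compound 3 to compound 4, 3.5 percentage points apart, within the scatter of two such steps. Isopropyl in place of hydroxy, this time on the free acids, gives a number 3.4 percentage points lower from compound 2 to compound 4 (within the scatter), and this change also carries over between cores: the same change on two cores in this assay, a number 6.9 percentage points lower (within the scatter) from compound 1 to compound 3 and a number 3.4 percentage points lower (within the scatter) from compound 2 to compound 4, 3.5 percentage points apart, within the scatter of two such steps. So in these four compounds each change behaves alike on both cores, but all of these steps lie within the scatter, so this does not show that either change really alters the effect, or that it would carry over to further cores.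

As far as these compounds go, what ethyl in place of benzyl on that oxygen would give remains open. So does the effect of an amine or a longer chain in place of hydroxy or isopropyl.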